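Shortening the Branched Chain of a Potent Imide Carbamate

The source may report more compounds than this note shows. Statements on the series, on what has been measured and on what is new or still open speak of the compounds shown alone.

Compound 3 `CCCCCCCCCCCCC(C)(C)OC(=O)NC(=O)Oc1c(C(C)C)cccc1C(C)C` gives 21 nM in an assay on microsomes from intestine for inhibition of acyl-CoA:cholesterol acyltransferase (Oryctolagus cuniculus) (on this read-out higher numbers stand for weaker inhibition and lower numbers for stronger inhibition), the lowest of the three numbers shown and therefore the strongest inhibitor among them. Compound 1 `CCCCCCOC(=O)NC(=O)Oc1c(C(C)C)cccc1C(C)C` gives 53 nM, and compound 2 `CCCCCCCCOC(=O)NC(=O)Oc1c(C(C)C)cccc1C(C)C` gives 250 nM. Compound 4 `CCCCC(C)(C)OC(=O)NC(=O)Oc1c(C(C)C)cccc1C(C)C` differs from compound 3 by hydrogen in place of octyl on a saturated chain carbon, five bonds along the chain from an oxygen next to a carbonyl group. Going by the values given here, the only measured step that alters chain length is a 4.7-fold higher number from compound 1 to compound 2 (0.67 log units; beyond the scatter), where a longer chain weakened inhibition; yet compound 3, carrying the longest chain of all, stands strongest, so chain length does not pull in one direction across these compounds. A shorter chain is thus expected to move the number only modestly, most likely upward, giving a 2.1-fold higher number from compound 3 to compound 4 (0.33 log units; beyond the scatter). Compound 4 is estimated at 45 nM, within 12 nM to 170 nM.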

Compound 4, half-maximal inhibitory concentration: 64 nM
For compound 4 the middle estimate is 1.4-fold (0.15 log units) below the measured one; the range from low to high includes it.
By their numbers in this assay, from the lowest: compound 3; then compounds 1 and 4 (each within the scatter of the next); then compound 2.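

In this assay, hydrogen in place of octyl at this saturated chain carbon gives a clear change (a 3.0-fold higher number from compound 3 to compound 4 (0.48 log units; beyond the scatter)), so the far end of the long branched chain does affect the number. The shortened 1,1-dimethylpentyl group cannot be told apart from hexyl (a 1.2-fold higher number from compound 1 to compound 4 (0.08 log units; within the scatter)), yet it differs clearly from octyl (a 3.9-fold lower number from compound 2 to compound 4 (0.59 log units; beyond the scatter)). No measured evidence accounts for these shifts. Open, from the compounds shown here alone, is how the number behaves with butyl at this carbon, and whether a chain ending in a carboxylic acid or an amine is tolerated.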